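Same Atoms, Joined Differently, on a Shared Core

The source may hold more compounds than are shown below. What is called first, only, known or untested is meant among the compounds shown, and "the series" means these compounds.

In a functional assay on a cell-free system (Platelet, plasma, Homo sapiens) for inhibition (on this read-out lower numbers stand for stronger inhibition and higher numbers for weaker inhibition), compound 1 (`N=C(N)N1CCCC(C(=O)Nc2cccc(OCc3ccc(F)cc3)c2)C1`) gives 274000 nM as the second highest of three numbers, while compound 2 (`N=C(N)N1CCCC(C(=O)Nc2cccc(OCc3ccc(-c4ccccc4)cc3)c2)C1`) gives 1000000 nM and compound 3 (`O=C(Nc1cccc(OCc2ccc(-c3ccc(F)cc3)cc2)c1)C1CCNCC1`) gives 35000 nM as the lowest. Compound 4 (`N=C(N)N1CCC(C(=O)Nc2cccc(OCc3ccc(F)cc3)c2)CC1`) has the atoms of compound 1 joined differently, with a group of 9 heavy atoms (6 carbon, 3 nitrogen; one six-membered non-aromatic ring with 1 hetero atom) in place of a group of 9 heavy atoms (6 carbon, 3 nitrogen; one six-membered non-aromatic ring with 1 hetero atom), on a carbonyl carbon as the change. Within the data shown here, the one measured step, a 3.6-fold higher number from compound 1 to compound 2 (0.56 log units; beyond the scatter) for phenyl in place of fluoro, lies in a different place and says little here. Among the measured compounds shown here, no measured pair tests this change alone, so only a modest move towards lower numbers is expected, since compound 3 at 35000 nM shares the ring joining of compound 4 while differing elsewhere. In this assay the estimated move is a 2.3-fold lower number from compound 1 to compound 4 (0.36 log units; beyond the scatter) with wide uncertainty. For compound 4 the estimate is 120000 nM with a range from 35000 nM to 400000 nM as expected bounds.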

Compound 4, half-maximal inhibitory concentration: 768000 nM
Estimate against measurement, compound 4: 6.4-fold (0.81 log units) below, and the stated range ends below it.
By their numbers in this assay, from the lowest: compound 3; then compound 1; then compounds 4 and 2 (each within the scatter of the next).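

Joining the same atoms differently on the carbonyl carbon is not a neutral change in this assay: it gives a 2.8-fold higher number from compound 1 to compound 4 (0.45 log units; beyond the scatter), a modest step beyond the scatter. This position therefore responds to how the ring is joined, even though the atom counts of the group stay the same. No measurement here explains the direction of this step. As far as these compounds go, it remains open whether the step would keep its direction and size with phenyl in place of fluoro. From the compounds shown here alone, how a carboxylic acid or an amine on a longer chain would fare on this carbonyl carbon also remains open.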